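Swapping a Pyrimidine for Methoxy on an Amide Nitrogen

The source may hold more compounds than are shown below. What is called first, only, known or untested is meant among the compounds shown, and "the series" means these compounds.

Measured compounds:
compound 1 `Cc1ccc(OCC(=O)N(Cc2cccs2)c2ncccn2)cc1` — 3700 nM
compound 2 `CCN(Cc1cccs1)C(=O)C[C@H](O)c1ccccc1` — 52000 nM
compound 3 `CCN(Cc1ccsc1)C(=O)COc1ccc(C)cc1` — 88 nM

All three were tested in an assay on HEK293 cells for agonist activity at transient receptor potential cation channel subfamily M member 8 (Homo sapiens), read by fluorescence and calcium flux, with a stated time of 15 min; on this read-out lower numbers stand for an effect already at smaller amounts and higher numbers for an effect only at larger amounts of compound. Among the three numbers, compound 1 stands second highest with 3700 nM. Compound 2 gives 52000 nM, a higher number beyond the scatter, while compound 3 gives 88 nM, a lower number also beyond the scatter.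

Compound 4 `CON(Cc1cccs1)C(=O)COc1ccc(C)cc1` has not yet been measured. It differs from compound 1 in one place: methoxy in place of pyrimidin-2-yl on an amide-type nitrogen

For the measured compounds named here, no step between two measured compounds that differ in only one place is available, so the size of this change cannot be read directly. Compound 3, which carries an ethyl group on its amide-type nitrogen rather than a ring, differs from compound 1 in more than one place and is only a rough guide. Compound 4 is expected to give 400 nM, within a range from 80 nM to 2500 nM. That estimate corresponds to a step of a 9.3-fold lower number from compound 1 to compound 4 (0.97 log units; beyond the scatter) toward a lower number, expected to lie beyond the scatter.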

Compound 4, half-maximal effective concentration: 10 nM
Estimate against measurement, compound 4: 40-fold (1.60 log units) above; measured number below the stated range.
By their numbers in this assay, from the lowest: compound 4; then compound 3; then compound 1; then compound 2.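

In this assay, for the compounds shown here, the single change from pyrimidin-2-yl to methoxy on the amide-type nitrogen gives a 370-fold lower number from compound 1 to compound 4 (2.57 log units; beyond the scatter), so what sits at this position strongly affects the read-out. This step also shows that a six-membered aromatic ring is not needed on this nitrogen for an effect at small amounts of compound: the entering methoxy has no ring and fewer heavy atoms. Nothing available explains why the swap has so large an effect.

Compound 3 carries ethyl on this nitrogen but differs from the others in more than one place, so steps involving it cannot be read. The compounds shown leave open whether the low number depends on the oxygen of methoxy, and whether ethoxy or a longer chain such as propoxy on the same nitrogen would give a similar number.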